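A few compounds are considered here, and "the series" means these few. Any claim that something is new, unique, unknown or untested is made for them only; others in the source may bear on it.

Measured so far:
- compound 1 `NC(=O)c1ccc(C(=O)Nc2cc(-c3ccccc3)nn2-c2ccccc2)cc1` — > 10000 nM
- compound 2 `O=C(O)c1ccc(C(=O)Nc2cc(-c3ccccc3)nn2-c2ccccc2)cc1` — > 10000 nM

Both values come from an assay on HEK293 cells for displacement of a labelled ligand from metabotropic glutamate receptor 5 (Rattus norvegicus); a higher number here means a weaker inhibitor, a lower number a stronger inhibitor. For compound 1 the value of > 10000 nM is a limit, not a number. For compound 2 the value of > 10000 nM is likewise a limit. Compound 2 therefore stands at the edge of what this assay can report, and the limit of > 10000 nM in this assay, at which 2 of the 2 values shown sit, holds for every value shown.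

Compound 3 `COc1cc(OC)cc(C(=O)Nc2cc(-c3ccccc3)nn2-c2ccccc2)c1` differs from compound 2 by 3,5-dimethoxyphenyl in place of 4-carboxyphenyl on a carbonyl carbon. Among the compounds with values here, the only step measured so far, a step that the two limits leave unreadable from compound 1 to compound 2, runs between two limits, so its size cannot be read, and it leaves the carbonyl-bearing group as the only place where anything has been changed. Within the data shown here, no measured step shows how this assay responds to an aryl group without a hydrogen-bond donor, so the expectation for compound 3 rests on weak ground.

Compound 3 is expected to give about 8000 nM in this assay, within 1500 nM to 30000 nM. The step this implies, an at least 1.2-fold lower number from compound 2 to compound 3 (0.09 log units; that floor lies within the scatter), is an estimate that may again end as a limit.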

Compound 3, inhibition constant: > 10000 nM
Compound 3 was reported as a limit; the forecaster's own chance of this, stated with the estimate: 55%; middle value at least 1.2-fold (0.09 log units) away from the limit.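

In this assay compound 3 gives > 10000 nM, a limit and not a number. The steps to compound 3 from compound 1 and compound 2 cannot be read, as each runs between two limits: the limit of > 10000 nM in this assay, at which 3 of the 3 values shown sit.

The compounds shown leave open whether any group on this carbonyl carbon gives a measurable value.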